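This account rests on a few compounds, and the source may have more. Where it says the series, first, only, none or still open, it means among the compounds named here.

Compound 3 `CC1CCCN(C(=O)CN2CN(c3ccccc3)C3(CCN(C(=O)c4ccc(C(C)(C)C)cc4)CC3)C2=O)C1` gives 12000 nM in an assay on HEK293 cells for displacement of a labelled ligand from NPC1-like intracellular cholesterol transporter 1 (Homo sapiens) (on this read-out lower numbers stand for stronger inhibition and higher numbers for weaker inhibition), the highest of the three numbers measured. Compound 2 `CC(C)(C)c1ccc(C(=O)N2CCC3(CC2)C(=O)N(CC(=O)NCCCNS(C)(=O)=O)CN3c2ccccc2)cc1` gives 10400 nM, and the step between them is a 1.2-fold higher number from compound 2 to compound 3 (0.06 log units; within the scatter). Compound 1 `CC(C)(C)c1ccc(C(=O)N2CCC3(CC2)C(=O)N(CC(=O)NCNS(C)(=O)=O)CN3c2ccccc2)cc1` gives 3200 nM, a step of a 3.8-fold higher number from compound 1 to compound 3 (0.57 log units; beyond the scatter). Compound 4 `CC(C)(C)c1ccc(C(=O)N2CCC3(CC2)C(=O)N(CC(=O)N2CCCC(CO)C2)CN3c2ccccc2)cc1` differs from compound 3 by hydroxy in place of hydrogen on a saturated chain carbon bound to a saturated ring carbon. Going by the values given here, none of the measured steps, including a 3.3-fold higher number from compound 1 to compound 2 (0.51 log units; beyond the scatter), swaps a hydrogen for a hydroxy, so nothing measured here bears directly on this change; the known steps concern other parts of the molecule. For compound 4 the expected step is therefore a 1.2-fold lower number from compound 3 to compound 4 (0.08 log units; within the scatter), within the scatter. The estimate for compound 4 is 10000 nM, with a likely range from 4000 nM to 30000 nM.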

Compound 4, half-maximal inhibitory concentration: 8200 nM
For compound 4 the middle estimate is 1.2-fold (0.09 log units) above the measured one, and the stated range covers the measured number.
By their numbers in this assay, from the lowest: compound 1; then compounds 4, 2 and 3 (each within the scatter of the next).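

Turning methyl into hydroxymethyl on the piperidine amide gives only a small step, within the scatter (a 1.5-fold lower number from compound 3 to compound 4 (0.17 log units; within the scatter)), so this position tolerates a hydroxy here. The 3-(hydroxymethyl)piperidin-1-yl group also lands level with the (3-(methanesulfonamido)propyl)amino group (a 1.3-fold lower number from compound 2 to compound 4 (0.10 log units; within the scatter)), yet it does not match the ((methanesulfonamido)methyl)amino group (a 2.6-fold higher number from compound 1 to compound 4 (0.41 log units; beyond the scatter)). No measured evidence accounts for these steps.

Still open, as far as these compounds go, is whether an amine or a carboxylic acid in place of the hydroxy, or a longer chain carrying the hydroxy, would shift the number beyond the scatter.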